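The source may report more compounds than this note shows. Statements on the series, on what has been measured and on what is new or still open speak of the compounds shown alone.

Measured compounds:
compound 1 `CC(=O)c1ccccc1OCc1ccc2no[n+]([O-])c2c1` — > 200 uM
compound 2 `N=C(N)N/N=C\c1ccccc1OCc1ccc2no[n+]([O-])c2c1` — 58 uM

In an ADME assay on cells (Erythrocyte, Homo sapiens), read by spectrophotometry and hemolysis, with a stated time of 24 h (on this read-out lower numbers stand for stronger inhibition and higher numbers for weaker inhibition), compound 1 gives only a limit, > 200 uM. For the measured compounds named here, compound 2 holds the only number in this assay, 58 uM. The other value shown, that of compound 1, is a limit. Going by the values given here, the one measured step, an at least 3.4-fold lower number from compound 1 to compound 2 (0.53 log units; beyond the scatter), sits against (the limit of > 200 uM in this assay, at which 1 of the 2 values shown sits).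

Compound 3 `C=CCNC(=S)N/N=C\c1ccccc1OCc1ccc2no[n+]([O-])c2c1` is unmeasured. It differs from compound 2 by a group of 6 heavy atoms (4 carbon, 1 nitrogen, 1 sulfur; no ring) in place of a group of 3 heavy atoms (1 carbon, 2 nitrogen; no ring), on an amine nitrogen. Among the compounds with values here, no measured step touches this position: the step from compound 1 to compound 2 changes a different group on an aromatic carbon, and its lower end is fixed by a limit rather than a number. It therefore gives no direction for the present change, and no step beyond the scatter is expected here.

Compound 3 is estimated at 45 uM, range 12 uM to 170 uM. The expected step of a 1.3-fold lower number from compound 2 to compound 3 (0.11 log units; within the scatter) is a guess anchored on compound 2 alone.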

Compound 3, concentration for 50% inhibition: 139 uM
Compound 3: the middle estimate sits 3.1-fold (0.49 log units) below what was measured; the measured number falls inside the stated range.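

In this assay, the amine nitrogen turns out to be a position that responds to change: the group of 6 heavy atoms, with its sulfur, in place of the group of 3 heavy atoms gives a 2.4-fold higher number from compound 2 to compound 3 (0.38 log units; beyond the scatter). The lower number reached with compound 2 is therefore not kept by every group at this nitrogen. The comparison with the starting compound gives an at least 1.4-fold lower number from compound 1 to compound 3 (0.15 log units; that floor lies within the scatter), so compound 3 is not shown to differ from compound 1, whose value is a limit: the limit of > 200 uM in this assay, at which 1 of the 3 values shown sits.

The sulfur and the added carbon chain enter together, so the step cannot be assigned to either one. A group with oxygen in place of the sulfur, or with a methyl in place of the longer chain, would separate the two.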